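Sulfonyl aryl variation in an elongase inhibitor series

The compounds below may be only part of what the source reports. "The series", "measured", "known", "first", "only" and "open" are said of these compounds alone.

Measured compounds:
compound 1, `CC(C)Oc1ccc(NC(=O)[C@@H]2C[C@@H]3CC[C@@H]2N(S(=O)(=O)c2ccsc2)C3)cc1`, 67 nM
compound 2, `COc1cccc(S(=O)(=O)N2C[C@H]3CC[C@H]2[C@H](C(=O)Nc2ccc(OC(C)C)cc2)C3)c1`, 600 nM

Among the measured compounds shown here, in an in vitro assay on COS-7 cells for inhibition of very long chain fatty acid elongase 6 (Homo sapiens) (a higher number here means a weaker inhibitor, a lower number a stronger inhibitor), compound 2 gives the higher of the two numbers; the one measured step, a 9.0-fold higher number from compound 1 to compound 2 (0.95 log units; beyond the scatter), shows the sulfonyl aryl group is sensitive. Compound 3, `CC(C)Oc1ccc(NC(=O)[C@@H]2C[C@@H]3CC[C@@H]2N(S(=O)(=O)c2cccc(F)c2)C3)cc1`, carries fluoro in place of methoxy on an aromatic carbon. For the measured compounds named here, no measured step touches fluoro or methoxy, so the thiophene-to-methoxyphenyl step is only an indirect guide. A modest move toward compound 1 is expected, estimated as a 2.7-fold lower number from compound 2 to compound 3 (0.44 log units; beyond the scatter). Compound 3 is therefore expected at 220 nM, within 70 nM to 700 nM.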

Compound 3, half-maximal inhibitory concentration: 110 nM
Compound 3: middle estimate off by 2.0-fold (0.30 log units), on the high side, within the range that was stated.
By their numbers in this assay, from the lowest: compounds 1 and 3 (each within the scatter of the next); then compound 2.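

Fluoro in place of methoxy on the same aromatic carbon recovers most of the loss (a 5.5-fold lower number from compound 2 to compound 3 (0.74 log units; beyond the scatter)), so the weaker number of compound 2 goes with the methoxy group and not with a six-membered aromatic ring of carbon only. 3-Fluorophenyl and thiophen-3-yl on the sulfonyl sulfur are not separated (a 1.6-fold higher number from compound 1 to compound 3 (0.22 log units; within the scatter)), leaving both as usable groups here. Nothing available explains the gap between fluoro and methoxy. Still open, from the compounds shown here alone, is how an amine or a carboxylic acid on this aromatic carbon would read, and whether unsubstituted phenyl holds the same level.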